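Compound 3 after two limit readings

This account rests on a few compounds, and the source may have more. Where it says the series, first, only, none or still open, it means among the compounds named here.

Compound 1 `CCCCCCCCOc1nc(N)nc2c1ncn2/C=C1/CC1(CO)CO`: > 300000 nM
Compound 2 `CN(C)c1nc(N)nc2c1ncn2/C=C1/CC1(CO)CO`: > 300000 nM
Compound 3 `Nc1nc(N2CCCC2)c2ncn(/C=C3/CC3(CO)CO)c2n1`: not yet measured

In an ADME assay on HFF cells (Homo sapiens) for cytotoxicity, with a stated time of 8 days (a higher number here means that more compound is tolerated, a lower number that less compound is tolerated), compound 2 gives > 300000 nM, which is a limit and not a number. Compound 1 gives > 300000 nM, which is also a limit. Both readings therefore sit together: the limit of > 300000 nM in this assay, at which 2 of the 2 values shown sit.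

Compound 3 keeps the shared core of compound 2 and changes one group, with pyrrolidin-1-yl in place of dimethylamino on an aromatic carbon.

For the measured compounds named here, only one measured step bears on this place, and it has no size to carry over: a step that the two limits leave unreadable from compound 1 to compound 2. Even so, swapping octyloxy for dimethylamino left both compounds at the limit, so no shift beyond the scatter is expected in this assay, and no direction is favoured.

The expected change is a number no higher from compound 2 to compound 3 (the limit leaves the size open). For compound 3 the estimate is 300000 nM, with an expected range from 120000 nM to 500000 nM, and another limit is the likeliest report.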

Compound 3, half-maximal cytotoxic concentration: > 300000 nM
Compound 3: no number, only a limit; the forecaster's own chance of this, stated with the estimate: 75%; the middle value lies on the limit itself.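

In this assay compound 3 gives > 300000 nM, again a limit and not a number. For the compounds shown here, no step among compound 1, compound 2 and compound 3 can be read: the limit of > 300000 nM in this assay, at which 3 of the 3 values shown sit. Where the true half-maximal cytotoxic concentration of each compound lies, and whether the three groups differ at all, stays open.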